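Moving from a Methoxy Back to a Hydroxyl, with a Ring Methyl

The source may hold more compounds than are shown below. What is called first, only, known or untested is meant among the compounds shown, and "the series" means these compounds.

Compound 3 `C=C/C=C\[C@H](C)[C@H](OC(N)=O)[C@@H](C)[C@H](O)[C@@H](C)C/C(C)=C\[C@H](C)[C@@H](O)[C@@H](C)/C=C\CCc1cccc(OC)c1` is one of three related compounds measured in a functional assay on MCF7 cells (Homo sapiens) for cytotoxicity; on this read-out lower numbers stand for stronger inhibition and higher numbers for weaker inhibition. Compound 3 gives 330 nM, which places it second highest of the three numbers: compound 1 `C=C/C=C\[C@H](C)[C@H](OC(N)=O)[C@@H](C)[C@H](O)[C@@H](C)C/C(C)=C\[C@H](C)[C@@H](O)[C@@H](C)/C=C\CCc1cccc(O)c1` gives 130 nM, and compound 2 `C=C/C=C\[C@H](C)[C@H](OC(N)=O)[C@@H](C)[C@H](O)[C@@H](C)C/C(C)=C\[C@H](C)[C@@H](O)[C@@H](C)/C=C\CCc1ccsc1` gives 850 nM. The measured steps show a 2.5-fold higher number from compound 1 to compound 3 (0.40 log units; beyond the scatter), a 6.5-fold higher number from compound 1 to compound 2 (0.82 log units; beyond the scatter) and a 2.6-fold lower number from compound 2 to compound 3 (0.41 log units; beyond the scatter).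

Compound 4 `C=C/C=C\[C@H](C)[C@H](OC(N)=O)[C@@H](C)[C@H](O)[C@@H](C)C/C(C)=C\[C@H](C)[C@@H](O)[C@@H](C)/C=C\CCc1cccc(O)c1C` has not yet been measured. It differs from compound 3 in one place: 3-hydroxy-2-methylphenyl in place of 3-methoxyphenyl on a saturated chain carbon, two bonds along the chain from a double-bonded chain carbon. In plain terms, the methyl that sat on the oxygen in compound 3 is gone, so the ring again carries a free hydroxyl as in compound 1, while a methyl now sits on the ring itself.

The step that bears most directly on this change is a 2.5-fold higher number from compound 1 to compound 3 (0.40 log units; beyond the scatter), which shows that putting a methyl on the ring oxygen raised the number modestly. Undoing that should lower it by a similar amount. Going by the values given here, no measured step shows the effect of a methyl on the ring, so that part stays uncertain. The estimate for compound 4 is therefore a 2.2-fold lower number from compound 3 to compound 4 (0.34 log units; beyond the scatter), giving an expected value of 150 nM, with a range from 60 nM to 400 nM.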

Compound 4, half-maximal inhibitory concentration: 490 nM
Compound 4: middle estimate off by 3.3-fold (0.51 log units), on the low side; the measured number lies above the stated range.
By their numbers in this assay, from the lowest: compound 1; then compounds 3, 4 and 2 (each within the scatter of the next, the first and the last beyond it).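

In this assay, going by these compounds alone, a methyl in place of hydrogen on an aromatic carbon gives a 3.8-fold higher number from compound 1 to compound 4 (0.58 log units; beyond the scatter), the first direct look at a ring methyl, and it shows that the free hydroxyl of compound 1 does not keep its lower number once that methyl is present. Setting 3-hydroxy-2-methylphenyl in place of 3-methoxyphenyl gives a 1.5-fold higher number from compound 3 to compound 4 (0.17 log units; within the scatter), and setting it in place of thiophen-3-yl gives a 1.7-fold lower number from compound 2 to compound 4 (0.24 log units; within the scatter); both steps lie within the scatter, so compound 4 cannot be separated from either compound, even though compound 2 and compound 3 are separated from each other. No supporting measurement is available to explain why the ring methyl has this effect.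

The compounds shown leave open whether a ring methyl would have a similar effect on the 3-methoxyphenyl group, or whether a fluorine in its place would have the same effect as the methyl. As far as these compounds go, it also remains open how an amine in place of the hydroxyl, or a longer chain leading to the ring, would behave.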